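A benzylsulfanyl analogue among three well-tolerated compounds

The source may hold more compounds than are shown below. What is called first, only, known or untested is meant among the compounds shown, and "the series" means these compounds.

The series comprises compound 1 `CCCCNc1nc(N)nc2c1ncn2/C=C1/CC1(CO)CO`, compound 2 `CCCCCCCCSc1nc(N)nc2c1ncn2/C=C1/CC1(CO)CO` and compound 3 `COCCOc1nc(N)nc2c1ncn2/C=C1/CC1(CO)CO`. In an ADME assay on MOLT-3 cells (Homo sapiens) for cytotoxicity, with a stated time of 7 days (a higher number here means that more compound is tolerated, a lower number that less compound is tolerated), compound 1 gives only a limit, > 20000 nM. Compound 2 likewise gives a limit, > 20000 nM. Compound 3 also reaches only a limit, > 20000 nM, so it stands where the other two stand, as the limit of > 20000 nM in this assay, at which 3 of the 3 values shown sit, shows. The steps a step that the two limits leave unreadable from compound 1 to compound 2, a step that the two limits leave unreadable from compound 1 to compound 3 and a step that the two limits leave unreadable from compound 2 to compound 3 are therefore not readable in size or direction. Compound 4 `Nc1nc(SCc2ccccc2)c2ncn(/C=C3/CC3(CO)CO)c2n1` differs from compound 3 by benzylsulfanyl in place of 2-methoxyethoxy on an aromatic carbon. For the measured compounds named here, no measured step bears on this change, so no shift beyond the scatter is foreseen. Compound 4 is expected to show a step of a number no higher from compound 3 to compound 4 (the limit leaves the size open), with an estimated value of 20000 nM, between 10000 nM and 50000 nM, most likely reported again only as a limit.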

Compound 4, half-maximal cytotoxic concentration: > 20000 nM
Compound 4: a limit, no number (the forecaster's own chance of this, stated with the estimate: 80%); the middle value lies on the limit itself.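

Compound 4 also gives only a limit in this assay, so its steps from compound 1, compound 2 and compound 3 cannot be read: the limit of > 20000 nM in this assay, at which 4 of the 4 values shown sit. As far as these compounds go, how much of each of these four compounds is tolerated, and whether they differ at all, stays open.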